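The compounds below may be only part of what the source reports. "The series", "measured", "known", "first", "only" and "open" are said of these compounds alone.

The shared core of compound 1 `O=C(O)Cc1sc(C(c2ccc(F)cc2)c2ccc(F)cc2)nc1-c1ccnc(N2CCCC2)c1`, compound 2 `COc1ccc(C(c2ccccc2)c2nc(-c3ccc(Cl)cc3)c(CC(=O)O)s2)cc1` and compound 3 `O=C(O)Cc1sc(C(c2ccccc2)c2ccccc2)nc1-c1cccc(F)c1` is the same, and the three differ only in the groups hung on it. In an in vitro functional assay on HEK285-7 cells for antagonist activity at prostaglandin D2 receptor 2 (Homo sapiens), read by BRET and beta-arrestin recruitment (a higher number here means a weaker inhibitor, a lower number a stronger inhibitor), compound 1 returns > 100000 nM, which is a limit of the assay rather than a number (the limit of > 100000 nM in this assay, at which 1 of the 3 values shown sits). In this assay compound 2 gives 76 nM. In this assay compound 3 gives 29 nM. Compound 4 `CS(=O)(=O)Nc1cccc(-c2nc(C(c3ccc(F)cc3)c3ccc(F)cc3)sc2CC(=O)O)c1` is not yet measured; it differs from compound 1 in one place (3-(methanesulfonamido)phenyl in place of 2-(pyrrolidin-1-yl)pyridin-4-yl on an aromatic carbon), and the entering group resembles those found in compound 2 and compound 3 more than the group it replaces. Among the measured compounds shown here, since no measured pair shows this exact change, the expected step is an at least 1000-fold lower number from compound 1 to compound 4 (3.00 log units; beyond the scatter), a large gain in potency, well beyond the usual scatter. Compound 4 is therefore estimated at 100 nM, between 20 nM and 1500 nM.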

Compound 4, half-maximal inhibitory concentration: 370 nM
Compound 4: middle estimate off by 3.7-fold (0.57 log units), on the low side; the measured number falls inside the stated range.
By their numbers in this assay, from the lowest: compound 3; then compound 2; then compound 4. At a limit, above all of these: compound 1.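

Replacing 2-(pyrrolidin-1-yl)pyridin-4-yl with 3-(methanesulfonamido)phenyl on this aromatic carbon gives an at least 270-fold lower number from compound 1 to compound 4 (2.43 log units; beyond the scatter) in this assay, so the group at this one position can decide whether the core shows measurable inhibition. On these data alone, compound 1 gives only a limit and not a number, so the full size of this step remains unknown: the limit of > 100000 nM in this assay, at which 1 of the 4 values shown sits.

The ring and its substituent change together, so the roles of the pyrrolidine, the ring nitrogen and the methanesulfonamido group cannot be separated. A 2-(pyrrolidin-1-yl)phenyl group at this position, or a pyridine ring carrying methanesulfonamido, would help to pull them apart.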